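Nitro for cyano on the benzamide of compound 3

The compounds below may be only part of what the source reports. "The series", "measured", "known", "first", "only" and "open" are said of these compounds alone.

Within the data shown here, compound 3 `N#Cc1ccc(C(=O)Nc2cccc(-c3oc4cc(-c5ccc(F)cc5)ccc4c(=O)c3O)c2)cc1` gives 7110 nM in a functional assay on HepG2 cells (Homo sapiens) for antiproliferative activity, read by CCK-8 assay, with a stated time of 72 h (on this read-out lower numbers stand for stronger inhibition and higher numbers for weaker inhibition), the highest of the two numbers so far; compound 1 `O=C(Nc1cccc(-c2oc3cc(-c4ccc(F)cc4)ccc3c(=O)c2O)c1)c1cc(F)cc(F)c1` sits nearest with 4960 nM, which is a 1.4-fold higher number from compound 1 to compound 3 (0.16 log units; within the scatter). Compound 2 `O=C(Nc1cccc(-c2oc3cc(-c4ccc(F)cc4)ccc3c(=O)c2O)c1)c1cnc(Cl)nc1Cl` returns only a limit in this assay, > 100000 nM; that limit is the one at the limit of > 100000 nM in this assay, at which 1 of the 3 values shown sits. Compound 4 `O=C(Nc1cccc(-c2oc3cc(-c4ccc(F)cc4)ccc3c(=O)c2O)c1)c1ccc([N+](=O)[O-])cc1` carries nitro in place of cyano on an aromatic carbon. Among the measured compounds shown here, no measured step changes a single group on that ring; the two large steps, an at least 20-fold higher number from compound 1 to compound 2 (1.30 log units; beyond the scatter) and an at least 14-fold lower number from compound 2 to compound 3 (1.14 log units; beyond the scatter), each exchange the whole aryl on the carbonyl carbon, and the only aryl-to-aryl step without a limit, from compound 1 to compound 3, is within the scatter. For the measured compounds named here, two acceptors enter where one leaves, but no measured step shows what that does here. The expectation for compound 4 is therefore a step of a 1.0-fold lower number from compound 3 to compound 4 (0.01 log units; within the scatter), not clearly beyond the scatter. Compound 4 is estimated at 7000 nM, with a range from 2500 nM to 20000 nM.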

Compound 4, half-maximal inhibitory concentration: 1860 nM
Estimate against measurement, compound 4: 3.8-fold (0.58 log units) above; measured number outside the range, below it.
By their numbers in this assay, from the lowest: compound 4; then compounds 1 and 3 (each within the scatter of the next). At a limit, above all of these: compound 2.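

Among these compounds, on an aromatic carbon para to a large group, nitro in place of cyano is the first change of a single group on this ring, and it reads beyond the scatter in this assay: a 3.8-fold lower number from compound 3 to compound 4 (0.58 log units; beyond the scatter). The benzamide end therefore does more than the earlier within-scatter step between aryl groups suggested, as a second comparison also shows: a 2.7-fold lower number from compound 1 to compound 4 (0.43 log units; beyond the scatter). The step of an at least 53-fold lower number from compound 2 to compound 4 (1.73 log units; beyond the scatter) is only a bound, since its starting value is a limit of the assay and not a number: the limit of > 100000 nM in this assay, at which 1 of the 4 values shown sits.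

The compounds shown compare only cyano and nitro on this carbon, so an amine, a carboxylic acid or a trifluoromethyl group there would show whether the lower number is particular to nitro. Also open, as far as these compounds go, is whether nitro gives a similar step when placed on the 3,5-difluorophenyl ring.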